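This account rests on a few compounds, and the source may have more. Where it says the series, first, only, none or still open, it means among the compounds named here.

Working notes on the amide series sharing one core. Compound 1 `COc1ccc(CN(C(=O)CCl)c2cc(OC)c(OC)c(OC)c2)cc1O` carries a chloromethyl on the carbonyl carbon; in a functional assay on KYSE-450 cells (Homo sapiens) for inhibition, read by MTT assay, with a stated time of 48 h (a higher number here means a weaker inhibitor, a lower number a stronger inhibitor), compound 1 gives 210 nM. Compound 2 `C=C(C)C(=O)N(Cc1ccc(OC)c(O)c1)c1cc(OC)c(OC)c(OC)c1` replaces it with 1-methylethenyl, and in this assay compound 2 gives 200 nM, so that a 1.1-fold lower number from compound 1 to compound 2 (0.02 log units; within the scatter). Compound 3 `COc1ccc(CN(C(=O)CN=[N+]=[N-])c2cc(OC)c(OC)c(OC)c2)cc1O` puts azidomethyl on the carbonyl carbon; in this assay compound 3 gives 160 nM. This is the lowest of the three numbers, yet both neighbours sit within the scatter of it: a 1.3-fold lower number from compound 1 to compound 3 (0.12 log units; within the scatter) and a 1.3-fold lower number from compound 2 to compound 3 (0.10 log units; within the scatter). Across the three acyl variants the group on the carbonyl carbon has not moved the number beyond the scatter.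

Compound 4 `CC/C=C/C(=O)N(Cc1ccc(OC)c(O)c1)c1cc(OC)c(OC)c(OC)c1` is the next step from compound 3: but-1-en-1-yl in place of azidomethyl on a carbonyl carbon. Among the compounds with values here, the steps that bear on it are the acyl swaps already measured, chloromethyl to 1-methylethenyl and 1-methylethenyl to azidomethyl, each within the scatter. A fourth acyl group is therefore expected to leave the number about where the others lie, with no direction beyond the scatter; the expected step is a 1.3-fold higher number from compound 3 to compound 4 (0.10 log units; within the scatter). For compound 4 in this assay the estimate is 200 nM, with a range from 100 nM to 450 nM.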

Compound 4, half-maximal inhibitory concentration: 72 nM
Compound 4: middle estimate off by 2.8-fold (0.44 log units), on the high side; measured number outside the range, below it.
By their numbers in this assay, from the lowest: compound 4; then compounds 3, 2 and 1 (each within the scatter of the next).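

In this assay the group on the carbonyl carbon can move the number beyond the scatter after all: but-1-en-1-yl separates from all three earlier acyl groups, which stayed within the scatter of one another, with modest steps in each comparison (a 2.2-fold lower number from compound 3 to compound 4 (0.35 log units; beyond the scatter)) (a 2.8-fold lower number from compound 2 to compound 4 (0.44 log units; beyond the scatter)) (a 2.9-fold lower number from compound 1 to compound 4 (0.46 log units; beyond the scatter)). A double bond in the group is not enough on its own to give this separation, since compound 2 also carries one in 1-methylethenyl and stays with compounds 1 and 3, so the four compounds show no simple pattern beyond compound 4 standing apart. Nothing at hand gives a reason for the difference between but-1-en-1-yl and the other groups.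

The compounds shown leave open whether the double bond of but-1-en-1-yl matters at all, as the saturated butyl group is not among them, and whether a longer chain such as hex-1-en-1-yl would carry the number further down. They also leave open how an amine on the chain, such as dimethylaminomethyl, or a phenyl group on the carbonyl carbon would compare with compound 4.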